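Nitro in place of cyano: expectation for compound 3

A few compounds are considered here, and "the series" means these few. Any claim that something is new, unique, unknown or untested is made for them only; others in the source may bear on it.

Measured in a functional assay on PC-3 cells (Homo sapiens) for cytotoxicity, read by MTT assay, with a stated time of 72 h; on this read-out higher numbers stand for weaker inhibition and lower numbers for stronger inhibition:
- compound 1 `O=C(N/N=C/c1ccc([N+](=O)[O-])cc1)Nc1cc2c(Nc3ccc(F)c(Cl)c3)ncnc2cc1O[C@H]1CCOC1` gives 33500 nM
- compound 2 `COc1cc2ncnc(Nc3ccc(F)c(Cl)c3)c2cc1NC(=O)N/N=C/c1ccc(C#N)cc1` gives 36500 nM

Compound 2 at 36500 nM lies within the scatter of compound 1 at 33500 nM, so these two numbers cannot be ranked. Compound 3 `COc1cc2ncnc(Nc3ccc(F)c(Cl)c3)c2cc1NC(=O)N/N=C/c1ccc([N+](=O)[O-])cc1` is the next to be read in this assay. It departs from compound 2 by one change: nitro in place of cyano on an aromatic carbon. In words, this is nitro in place of cyano on an aromatic carbon, para to a large group, or 4-cyanophenyl to 4-nitrophenyl. For the measured compounds named here, no measured pair shows this change alone, so the series offers no direct step size for it. The 4-nitrophenyl group is already present in compound 1, which gives 33500 nM, and this supports expecting no large departure. No step beyond the scatter is therefore expected, in either direction. The expected change is a 1.2-fold lower number from compound 2 to compound 3 (0.09 log units; within the scatter), an estimate that stays within the scatter. For compound 3 the estimated value is 30000 nM, with an expected range from 12000 nM to 60000 nM.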

Compound 3, half-maximal inhibitory concentration: 32400 nM
For compound 3 the middle estimate is 1.1-fold (0.03 log units) below the measured one, and the stated range covers the measured number.
By their numbers in this assay, from the lowest: compounds 3, 1 and 2 (each within the scatter of the next).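

In this assay the change from cyano to nitro on an aromatic carbon, para to a large group, now has a direct reading (a 1.1-fold lower number from compound 2 to compound 3 (0.05 log units; within the scatter)), so 4-cyanophenyl and 4-nitrophenyl cannot be told apart on the shared core at this level of scatter. For the compounds shown here, compound 3 also gives the first reading of the substituent on the oxygen on an aromatic ring with the 4-nitrophenyl group held fixed (a 1.0-fold lower number from compound 1 to compound 3 (0.01 log units; within the scatter)), and methyl and oxolan-3-yl cannot be told apart there either. Nothing available bears on why either pair reads alike.

Still open, going by these compounds, is whether any group at the para carbon of this aromatic ring, such as an amine or a carboxylic acid in place of nitro, would give a step beyond the scatter. The same holds for the oxygen on an aromatic ring, where a longer chain ending in an amine would test whether that place responds to anything larger than oxolan-3-yl.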